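This account rests on a few compounds, and the source may have more. Where it says the series, first, only, none or still open, it means among the compounds named here.

Measured compounds:
- compound 1, `Cc1c(OCCCCOc2ccc(Cl)c(C(=O)O)c2)ccc(C(=O)CC(C)(C)C)c1O`, 87 nM
- compound 2, `COc1cc(OCCCCOc2ccc(C(=O)CC(C)(C)C)c(O)c2C)cc(C(=O)O)c1`, 102 nM
- compound 3, `COc1ccc(C(=O)O)cc1OC[C@H](C)COc1ccc(C(=O)CC(C)(C)C)c(O)c1C`, 63 nM

The three measured compounds share the ketone-bearing phenol core and differ in the linker and in the substitution of the acid-bearing ring. In an assay for positive allosteric modulation of metabotropic glutamate receptor 2 (Rattus norvegicus) (a higher number here means that more compound is needed for the effect, a lower number that less compound is needed), compound 3 gives 63 nM, which is the lowest of the three numbers, but its distance to compound 1 and to compound 2 lies within the scatter of repeated measurements, so the three compounds cannot be ordered against one another on these data.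

Compound 4, `COc1ccc(C(=O)N(C)C)cc1OC[C@H](C)COc1ccc(C(=O)CC(C)(C)C)c(O)c1C`, is not yet measured. It differs from compound 3 in one place: dimethylamino in place of hydroxy on a carbonyl carbon, so that the carboxy group becomes a dimethylcarbamoyl group. Among the measured compounds shown here, all three measured compounds carry the carboxy group, and no pair among them shows what replacing it does in this assay; the expectation therefore rests on the structural change alone, with no measured step to lean on.

On that basis the step from compound 3 to compound 4 is expected to go toward a higher number, a 3.5-fold higher number from compound 3 to compound 4 (0.54 log units; beyond the scatter), with wide uncertainty in both directions. For compound 4 the expected value in this assay is 220 nM, within a range from 60 nM to 800 nM.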

Compound 4, half-maximal effective concentration: 5060 nM
Compound 4: middle estimate off by 23-fold (1.36 log units), on the low side; measured number outside the range, above it.
By their numbers in this assay, from the lowest: compounds 3, 1 and 2 (each within the scatter of the next); then compound 4.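

In this assay, among the compounds shown here, an 80-fold higher number from compound 3 to compound 4 (1.90 log units; beyond the scatter) gives the first measured reading at this position, on a carbonyl carbon whose other neighbour is an aromatic carbon. Compound 1, compound 2 and compound 3 all carry the carboxy group, so they could not show that exchanging it for dimethylcarbamoyl, with the rest of compound 3 unchanged, produces a large step beyond the scatter. At this position the assay therefore does not treat the dimethylcarbamoyl group as equivalent to the carboxy group, although this rests on a single pair, and no measurement shown explains the size of the step.

As far as these compounds go, it remains open whether the step follows from the loss of the hydroxy or from the entry of the dimethylamino group with its two methyl groups; a primary amide, an N-methyl amide, a methyl ester or a tetrazole at this place would help separate these readings. From the compounds shown here alone, it also remains open whether the same exchange gives a step of similar size on the linkers and acid-bearing rings of compound 1 and compound 2.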